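Amide variation on a stilbene cinnamamide core

The compounds below may be only part of what the source reports. "The series", "measured", "known", "first", "only" and "open" are said of these compounds alone.

Compound 1 `C#CCNC(=O)/C=C/c1c(/C=C/c2ccc(OC)cc2)cc(OC)cc1OC` is a cinnamamide bearing a propargylamino group on its carbonyl carbon. In a functional assay on MCF7 cells (Homo sapiens) for inhibition, read by MTT assay, with a stated time of 48 h (on this read-out lower numbers stand for stronger inhibition and higher numbers for weaker inhibition), compound 1 gives 4560 nM, the low end of the three numbers recorded, although the other two sit within the scatter of it. Compound 2 `COc1ccc(/C=C/c2cc(OC)cc(OC)c2/C=C/C(=O)N2CCC(Cl)CC2)cc1` carries a 4-chloropiperidin-1-yl group in place of the propargylamino group; in this assay compound 2 gives 4950 nM, a step of a 1.1-fold higher number from compound 1 to compound 2 (0.04 log units; within the scatter). Compound 3 `CCCCCN(CCCCC)C(=O)/C=C/c1c(/C=C/c2ccc(OC)cc2)cc(OC)cc1OC` carries a dipentylamino group instead; in this assay compound 3 gives 6130 nM, a step of a 1.3-fold higher number from compound 1 to compound 3 (0.13 log units; within the scatter), and between the two variants the step is a 1.2-fold higher number from compound 2 to compound 3 (0.09 log units; within the scatter). All three changes on the amide nitrogen thus stay within the scatter.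

Compound 4 `CCCCCCNC(=O)/C=C/c1c(/C=C/c2ccc(OC)cc2)cc(OC)cc1OC` differs from compound 1 only on the amide side: pentyl in place of ethynyl on a saturated chain carbon bound to an amide-type nitrogen. The steps from compound 1 to compound 2 and to compound 3 are the ones that bear on this change, as they also alter the group on the carbonyl carbon, and both were within the scatter. Compound 4 is therefore expected to show no step beyond the scatter, in either direction, with an estimated 1.1-fold higher number from compound 1 to compound 4 (0.04 log units; within the scatter). The estimate for compound 4 in this assay is 5000 nM, with a range from 2500 nM to 10000 nM.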

Compound 4, half-maximal inhibitory concentration: 5530 nM
Compound 4: the middle estimate sits 1.1-fold (0.04 log units) below what was measured; the measured number falls inside the stated range.
By their numbers in this assay, from the lowest: compounds 1, 2, 4 and 3 (each within the scatter of the next).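

In this assay, the exchange of ethynyl for pentyl keeps the amide hydrogen and alters only the chain, and it gives a 1.2-fold higher number from compound 1 to compound 4 (0.08 log units; within the scatter) even though the triple bond is lost and propargyl becomes hexyl, so neither the triple bond nor the added chain length separates the numbers at this position. Hexylamino on the carbonyl carbon also stays level with the two earlier groups, with a 1.1-fold lower number from compound 3 to compound 4 (0.04 log units; within the scatter) against dipentylamino and a 1.1-fold higher number from compound 2 to compound 4 (0.05 log units; within the scatter) against 4-chloropiperidin-1-yl, and among these four compounds neither the presence of the amide hydrogen nor a ring in the amine part sets any compound apart. Nothing among the data shown gives a reason for this flat picture.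

From the compounds shown here alone, it remains open whether an amine or a carboxylic acid carried on the hexyl chain, or a much shorter chain such as methyl, would move the number beyond the scatter. All four compounds also share the same core, so these steps say nothing about how changes to the methoxy groups or the alkene linkers would read.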